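Fluoro in Place of Hydrogen: An Expected Small Step

This account rests on a few compounds, and the source may have more. Where it says the series, first, only, none or still open, it means among the compounds named here.

Compound 1 `COc1cc(OC)c2c(=O)cc(/C=C/c3ccc([N+](=O)[O-])cc3)oc2c1` gives 19700 nM in a functional assay on A549 cells (Homo sapiens) for antiproliferative activity, read by MTT assay, with a stated time of 12 h; on this read-out lower numbers stand for stronger inhibition and higher numbers for weaker inhibition.
Compound 2 `COc1cc(OC)c2c(=O)cc(/C=C/c3ccccc3)oc2c1` gives 21500 nM in this assay.

Going by the values given here, compound 2 stands highest of these two numbers, yet the only measured step, a 1.1-fold higher number from compound 1 to compound 2 (0.04 log units; within the scatter), lies within the scatter. Compound 3 `COc1cc(OC)c2c(=O)cc(/C=C/c3ccc(F)cc3)oc2c1` differs from compound 2 by fluoro in place of hydrogen on an aromatic carbon, on a six-membered aromatic ring of carbon only, para to a large group. Since that one step at the same position did not move the number beyond the scatter, the step of a 1.0-fold lower number from compound 2 to compound 3 (0.01 log units; within the scatter) is expected to be none beyond the scatter. Compound 3 is therefore estimated at 21000 nM, between 10000 nM and 45000 nM.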

Compound 3, half-maximal inhibitory concentration: 18600 nM
The estimate for compound 3 lay 1.1-fold (0.05 log units) above the measured number, and the stated range covers the measured number.
By their numbers in this assay, from the lowest: compounds 3, 1 and 2 (each within the scatter of the next).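

In this assay fluoro in place of hydrogen gives a 1.2-fold lower number from compound 2 to compound 3 (0.06 log units; within the scatter) and fluoro in place of nitro gives a 1.1-fold lower number from compound 1 to compound 3 (0.02 log units; within the scatter) on the same aromatic carbon. This position, para to a large group, has now held hydrogen, nitro and fluoro, and no step among these three compounds leaves the scatter. No measurement shown here offers an explanation for this. Still open, as far as these compounds go, is whether an amine, a carboxylic acid or a longer chain at this place would give a step beyond the scatter. Equally open, from the compounds shown here alone, is whether a change elsewhere on the shared core would do so.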